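Butyryl in place of chlorobenzoyl on a tetrahydroquinoline amide

The source may hold more compounds than are shown below. What is called first, only, known or untested is meant among the compounds shown, and "the series" means these compounds.

Compound 1 `O=C(Nc1ccccc1C(F)(F)F)C1CCc2ccccc2N1C(=O)c1cccc(Cl)c1` stands at the low end of the three measured numbers in a functional assay on MDA-MB-231 cells (Homo sapiens) for cytotoxicity, read by sulforhodamine B assay, with a stated time of 72 h (on this read-out lower numbers stand for stronger inhibition of growth and higher numbers for weaker inhibition of growth), giving 288 nM. Compound 2 `O=C(Nc1cc(C(F)(F)F)cc(C(F)(F)F)c1)C1CCc2ccccc2N1C(=O)c1ccc(Cl)cc1` gives 2000 nM in this assay, and compound 3 `O=C(Nc1ccc(C(F)(F)F)cc1)C1CCc2ccccc2N1`, which carries no carbonyl group on the amide-type nitrogen in the ring, gives 24200 nM. Both gaps from compound 1 lie beyond the usual scatter, so compound 1 is the most potent of the three.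

Compound 4 `CCCC(=O)N1c2ccccc2CCC1C(=O)Nc1ccccc1C(F)(F)F` is not yet measured. It differs from compound 1 in one place: propyl in place of 3-chlorophenyl on a carbonyl carbon. Among the compounds with values here, no pair of measured compounds shows this same change, so its effect can only be guessed. The shift from compound 3 to compound 1 is very large, yet compound 3 also differs in the anilide, so it does not isolate the carbonyl substituent. Still, compound 1 288 nM and compound 3 24200 nM together suggest that the group on the ring nitrogen matters.

The writer expects a clear loss for compound 4, with a step of a 5.2-fold higher number from compound 1 to compound 4 (0.72 log units; beyond the scatter) beyond the scatter. The estimated value for compound 4 in this assay is 1500 nM, in a range from 400 nM to 6000 nM.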

Compound 4, concentration for 50% growth inhibition: > 70000 nM
Compound 4 gave a limit, no number; the forecaster's own chance of this, stated with the estimate: 5%; middle value at least 46-fold (1.66 log units) away from the limit.
By their numbers in this assay, from the lowest: compound 1; then compound 2; then compound 3. At a limit, above all of these: compound 4.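

Compound 4 gives > 70000 nM in this assay, a limit of the assay and not a number. Propyl in place of 3-chlorophenyl on a carbonyl carbon is the only single-place change among the compounds shown, and it gives an at least 240-fold higher number from compound 1 to compound 4 (2.38 log units; beyond the scatter), so the group on this carbonyl carbon has a large effect on growth inhibition when the anilide and the core stay the same. The true size of this step remains unknown, as only its lower bound can be read: the limit of > 70000 nM in this assay, at which 1 of the 4 values shown sits.

The compounds shown leave open whether the loss follows from removing the aromatic ring or the chlorine, as a benzoyl group without chlorine and a cyclohexyl group at this place would be needed to separate the two. They also do not show whether a longer chain than propyl would restore any activity.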